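The source may hold more compounds than are shown below. What is called first, only, known or untested is meant among the compounds shown, and "the series" means these compounds.

Compound 1, `Nc1cccc(CNc2cc(C(F)(F)F)cc3[nH]ncc23)c1`, gives 89% in an assay for inhibition of Tryptophan 2,3-dioxygenase (Homo sapiens), with stated times of 10 min and 60 min, tested at 100 uM; on this read-out higher numbers stand for a stronger effect at the one concentration tested and lower numbers for a weaker effect.
Compound 2, `Oc1ccc(CNc2cc(C(F)(F)F)cc3[nH]ncc23)cc1`, gives 91% in this assay.
Compound 3, `FC(F)(F)c1cc(NCc2cccc3sccc23)c2cn[nH]c2c1`, gives 5% in this assay.

Among the compounds with values here, of these three numbers, the one for compound 2 is the top value, but compound 1 sits right beside it: the step of a number 2 percentage points higher from compound 1 to compound 2 (within the scatter) lies within the usual scatter, so the two cannot be told apart. Compound 3, which carries a different ring on the carbon attached to the ring nitrogen, lies far lower.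

The next compound, compound 4, is `O=[N+]([O-])c1ccc(CNc2cc(C(F)(F)F)cc3[nH]ncc23)cc1`. Compared with compound 2, the change is nitro in place of hydroxy on an aromatic carbon, at the position described as para to a large group.

Within the data shown here, only one measured step bears on this position, the change from compound 1 to compound 2, and it stayed within the scatter. Among the measured compounds shown here, no measured step swaps a hydroxy for a nitro, so the direction of any effect is unknown. Given that compound 2 already gives 91% near the top of the scale, the expected step of a number 11 percentage points lower from compound 2 to compound 4 (beyond the scatter) is small, with a wide band allowing for a drop. Compound 4 is therefore estimated at 80%, with a range from 50% to 95% in this assay.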

Compound 4, a percentage reported as inhibition, at one concentration (the size of the read-out at that concentration, not a potency): 64%
For compound 4 the middle estimate is 16 percentage points above the measured one; the range from low to high includes it.
By their numbers in this assay, from the lowest: compound 3; then compound 4; then compounds 1 and 2 (each within the scatter of the next).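

Nitro in place of hydroxy on this aromatic carbon gives a number 27 percentage points lower from compound 2 to compound 4 (beyond the scatter) in this assay, so the group at this position can change the read-out by more than the usual scatter. The earlier step, a number 2 percentage points higher from compound 1 to compound 2 (within the scatter), could not show this, since it changed the group and its position on the ring and still left the two compounds indistinguishable, whereas compound 4 gives the first clear sign that the number depends on which group is attached to this six-membered aromatic ring, although compound 4 still retains 64% at the one concentration tested. No measurement shown here accounts for the size or direction of this step.

The compounds shown do not separate the effect of losing hydroxy from the effect of gaining nitro, and a methoxy group, a nitrile, an amine or a carboxylic acid on the same aromatic carbon, para to a large group, would help to tell these apart. A single number at one concentration also leaves open how compound 2 and compound 4 would compare at lower concentrations, where a stronger or weaker effect could be read.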